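Swapping nitro for cyano on a thiourea

This account rests on a few compounds, and the source may have more. Where it says the series, first, only, none or still open, it means among the compounds named here.

compound 1 `FC(F)(F)c1cccc(NC(=S)Nc2ccc(I)cc2)c1` gives 9100 nM
compound 2 `O=[N+]([O-])c1ccc(NC(=S)Nc2cccc(C(F)(F)F)c2)cc1` gives 8200 nM

In a functional assay on CCRF-SB cells (Homo sapiens) for cytotoxicity, read by MTT assay, with a stated time of 96 h (on this read-out lower numbers stand for higher toxicity in this test and higher numbers for lower toxicity in this test), compound 2 gives 8200 nM and lies within the usual scatter of compound 1 (9100 nM), so the two cannot be told apart. The next structure, compound 3 `N#Cc1ccc(NC(=S)Nc2cccc(C(F)(F)F)c2)cc1`, differs from compound 2 in one place, with cyano in place of nitro on an aromatic carbon. For the measured compounds named here, one measured step bears on this change: nitro in place of iodo on an aromatic carbon gave a 1.1-fold lower number from compound 1 to compound 2 (0.05 log units; within the scatter) and so stayed within the scatter. Going by the values given here, a single small step is thin evidence, and no measurement yet involves cyano. Even so, no step beyond the scatter is expected in this assay here. The estimated step is a 1.1-fold higher number from compound 2 to compound 3 (0.04 log units; within the scatter) and is expected to stay small. For compound 3 the estimated value is 9000 nM (expected range 4500 nM to 18000 nM).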

Compound 3, half-maximal cytotoxic concentration: 8300 nM
For compound 3 the middle estimate is 1.1-fold (0.04 log units) above the measured one, and the stated range covers the measured number.
By their numbers in this assay, from the lowest: compounds 2, 3 and 1 (each within the scatter of the next).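

In this assay, cyano in place of nitro gives a 1.0-fold higher number from compound 2 to compound 3 (0.01 log units; within the scatter), and cyano in place of iodo gives a 1.1-fold lower number from compound 1 to compound 3 (0.04 log units; within the scatter). Both steps stay within the scatter, so cyano now joins iodo and nitro as a third group at this place, on an aromatic carbon para to a large group, and the three compounds cannot be told apart in this test. Nothing available here explains why these three groups give such similar numbers.

The compounds shown leave open whether an amine, a carboxylic acid or a longer chain at this same place would give a step beyond the scatter. They also leave open how much the trifluoromethyl group of the shared core contributes to the numbers seen.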